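A bromine added to a second core

The compounds below may be only part of what the source reports. "The series", "measured", "known", "first", "only" and "open" are said of these compounds alone.

Measured so far:
compound 1, `CC(C)(C)c1ccc(-c2nnc(SCC(=O)c3ccccc3)o2)cc1`, 50 nM
compound 2, `COc1cc(OC)cc(-c2nnc(SCC(=O)c3ccccc3)o2)c1`, 170 nM
compound 3, `CC(C)(C)c1ccc(-c2nnc(SCC(=O)c3ccc(Br)cc3)o2)cc1`, 1950 nM

Of the compounds shown here, three have been tested in a functional assay on MCF7 cells (Homo sapiens) for cytotoxicity, read by MTT assay and propidium iodide staining, with a stated time of 24 h; a lower number here means a stronger inhibitor, a higher number a weaker inhibitor. Compound 1 gives 50 nM, compound 2 gives 170 nM, and compound 3 gives 1950 nM. Compound 3 is compound 1 carrying (bromo in place of hydrogen on an aromatic carbon), and that single change produced a 39-fold higher number from compound 1 to compound 3 (1.59 log units; beyond the scatter). Compound 2 differs from compound 1 in its core; the difference between the two cores is not broken down here. Compound 4 `COc1cc(OC)cc(-c2nnc(SCC(=O)c3ccc(Br)cc3)o2)c1` has not been measured. It stands to compound 2 as compound 3 stands to compound 1: it carries bromo in place of hydrogen on an aromatic carbon, the same change at the same place, made on the other core. Going by the values given here, only one measured pair shows what this change does, and there it weakened the compound strongly. Compound 4 is therefore expected to show a step of about a 26-fold higher number from compound 2 to compound 4 (1.42 log units; beyond the scatter), resting on the fact that the same change gave a 39-fold higher number from compound 1 to compound 3 (1.59 log units; beyond the scatter). Compound 4 is estimated at 4500 nM, with a likely range from 1500 nM to 15000 nM.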

Compound 4, half-maximal inhibitory concentration: 270 nM
For compound 4 the middle estimate is 17-fold (1.22 log units) above the measured one, outside the stated range (below it).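

In this assay, the change from phenyl to 4-bromophenyl did not carry over from one core to the other: on the core of compound 2 the step is a 1.6-fold higher number from compound 2 to compound 4 (0.20 log units; within the scatter), which leaves the two compounds indistinguishable, and the strong weakening seen on the core of compound 1 does not recur. Set side by side, the two steps clearly differ: the same change on two cores in this assay, a 39-fold higher number (1.59 log units; beyond the scatter) from compound 1 to compound 3 and a 1.6-fold higher number (0.20 log units; within the scatter) from compound 2 to compound 4, 25-fold (1.39 log units) apart, beyond the scatter of two such steps This shows that, in these two pairs, the outcome of the change depends on the core it is made on, but it does not show why the cores differ, and two pairs give no rule for any third core.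

The compounds shown leave open whether this dependence is specific to bromine or would also appear with another group in its place, such as a chlorine, an amine or a carboxylic acid. They also leave open how a single methoxy group on the core would behave under the same change.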